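Phenyl for pyrimidinyl on the piperazine of compound 3

The source may report more compounds than this note shows. Statements on the series, on what has been measured and on what is new or still open speak of the compounds shown alone.

Compound 3 `N#Cc1ccc(Nc2nc(Oc3ccnc4ccccc34)nc(N3CCN(c4ncccn4)CC3)n2)cc1C(F)(F)F` gives 85200 nM in a functional assay on DU-145 cells (Homo sapiens) for cytotoxicity, read by sulforhodamine B assay, with a stated time of 48 h (on this read-out lower numbers stand for stronger inhibition of growth and higher numbers for weaker inhibition of growth), the highest of the two numbers shown. Compound 1 `CC1CC(C)CN(c2nc(Nc3ccc(C#N)c(C(F)(F)F)c3)nc(Oc3ccnc4ccccc34)n2)C1` gives 27200 nM, and the step of a 3.1-fold higher number from compound 1 to compound 3 (0.50 log units; beyond the scatter) goes beyond the scatter. Compound 2 `COc1ccc(N2CCN(c3nc(Nc4ccc(C#N)c(C(F)(F)F)c4)nc(Oc4ccnc5ccccc45)n3)CC2)cc1` reaches only the limit > 100000 nM, which is a limit and not a number. The step of an at least 1.1-fold lower number from compound 2 to compound 3 (0.06 log units; that floor lies within the scatter) has a floor that lies within the scatter. Compound 4 `N#Cc1ccc(Nc2nc(Oc3ccnc4ccccc34)nc(N3CCN(c4ccccc4)CC3)n2)cc1C(F)(F)F` differs from compound 3 by phenyl in place of pyrimidin-2-yl on an amine nitrogen in a ring. Within the data shown here, the only bearing step is that from compound 2, where a 4-methoxyphenyl on the same ring nitrogen gave a limit; so the step of a 1.1-fold higher number from compound 3 to compound 4 (0.05 log units; within the scatter) is expected to stay within the scatter or lean toward a weaker number. Compound 4 is therefore estimated at 95000 nM, between 40000 nM and 220000 nM.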

Compound 4, concentration for 50% growth inhibition: > 100000 nM
Compound 4 gave a limit, no number; the forecaster's own chance of this, stated with the estimate: 40%; middle value at least 1.0-fold (0.02 log units) from the limit.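

Compound 4 gives only a limit, not a number, in this assay: > 100000 nM. Removing the two pyrimidine nitrogens gives an at least 1.1-fold higher number from compound 3 to compound 4 (0.06 log units; that floor lies within the scatter), so no effect of the swap can be read, while 4-phenylpiperazin-1-yl, with an at least 3.6-fold higher number from compound 1 to compound 4 (0.56 log units; beyond the scatter), joins 4-(pyrimidin-2-yl)piperazin-1-yl on the weaker side of 3,5-dimethylpiperidin-1-yl. The methoxy change between compound 2 and compound 4 cannot be read, because both values are limits: the limit of > 100000 nM in this assay, at which 2 of the 4 values shown sit.

On these data alone, what a methyl or an acetyl on that ring nitrogen would give remains open. So does the effect of a hydroxyl on the piperidine ring.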